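This account rests on a few compounds, and the source may have more. Where it says the series, first, only, none or still open, it means among the compounds named here.

Measured so far in a functional assay on HeLa cells (Homo sapiens) for antiproliferative activity, read by CCK-8 assay, with a stated time of 72 h, tested at 2 uM; on this read-out higher numbers stand for a stronger effect at the one concentration tested and lower numbers for a weaker effect:
compound 1, `CN(C(=S)SCc1ccc(C(=O)Nc2ccccc2N)cc1)c1cccnc1`, 16%
compound 2, `Nc1ccccc1NC(=O)c1ccc(CSC(=S)N2CCCc3ccccc32)cc1`, 26.1%

For the measured compounds named here, compound 2 holds the higher of the two numbers in this assay; its nearest neighbour is compound 1, and the step of a number 10.1 percentage points higher from compound 1 to compound 2 (beyond the scatter) is the only measured step. That step exchanges methyl(pyridin-3-yl)amino for 1,2,3,4-tetrahydroquinolin-1-yl on the thiocarbonyl carbon.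

Compound 3, `Nc1ccccc1NC(=O)c1ccc(CSC(=S)N2CCc3cc(Cl)ccc32)cc1`, is not yet measured in this assay. It differs from compound 2 by 5-chloro-2,3-dihydro-1H-indol-1-yl in place of 1,2,3,4-tetrahydroquinolin-1-yl on a thiocarbonyl carbon. Going by the values given here, no measured step bears on this change: the one step known, from compound 1 to compound 2, alters the same position but with a different pair of groups, and no compound carrying a 5-chloro-2,3-dihydro-1H-indol-1-yl group, or any chlorine, has been measured. Nothing in the numbers therefore points to a step beyond the scatter in either direction; the expectation is a step of about a number 0.1 percentage points lower from compound 2 to compound 3 (within the scatter), that is, none beyond the scatter.

Compound 3 is accordingly expected to give 26% in this assay, with a range from 12% to 42%.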

Compound 3, a percentage reported as inhibition, at one concentration (the size of the read-out at that concentration, not a potency): 40.1%
The estimate for compound 3 lay 14.1 percentage points below the measured number; measured number inside the range.
By their numbers in this assay, from the lowest: compound 1; then compound 2; then compound 3.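

In this assay, the position on the thiocarbonyl carbon, whose other neighbour is sulfur, tolerates a further change beyond the tetrahydroquinoline: 5-chloro-2,3-dihydro-1H-indol-1-yl in place of 1,2,3,4-tetrahydroquinolin-1-yl gives a number 14 percentage points higher from compound 2 to compound 3 (beyond the scatter), although the heavy-atom count stays the same and neither group carries hydrogen-bond donors or acceptors. Measured against methyl(pyridin-3-yl)amino, the same group gives a number 24.1 percentage points higher from compound 1 to compound 3 (beyond the scatter), so the three groups at this one position now give three separate levels, with every printed step among them beyond the scatter. Nothing available explains the rise.

Going by these compounds, the step from compound 2 to compound 3 changes the six-membered non-aromatic ring to a five-membered one and adds chlorine at the same time, so the share of each remains open; the parent 2,3-dihydro-1H-indol-1-yl group without chlorine and a chlorinated 1,2,3,4-tetrahydroquinolin-1-yl group would separate the two. Also open, on these data alone, is whether bromine, fluorine or a methoxy group could stand in for the chlorine, and whether the order of the compounds holds at other concentrations.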